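Bromine in Place of Chlorine on the Benzyl Ring

A few compounds are considered here, and "the series" means these few. Any claim that something is new, unique, unknown or untested is made for them only; others in the source may bear on it.

Among the three measured compounds, compound 3 `Cc1cc(Nc2nc(NCc3ccc(Cl)cc3)nc3[nH]ncc23)n[nH]1` gives the lowest number in an assay on isolated protein for inhibition of serine/threonine-protein kinase PAK 4 (Homo sapiens), read by HTRF, with a stated time of 60 min (a higher number here means a weaker inhibitor, a lower number a stronger inhibitor), at 515 nM. Compound 1 `Cc1cc(Nc2nc(NCc3ccccc3)nc3[nH]ncc23)n[nH]1` gives 1960 nM, and compound 2 `Cc1cc(Nc2nc(NCc3cccc(Br)c3)nc3[nH]ncc23)n[nH]1` gives 4340 nM. Compound 4 `Cc1cc(Nc2nc(NCc3ccc(Br)cc3)nc3[nH]ncc23)n[nH]1` differs from compound 3 by a single change: bromo in place of chloro on an aromatic carbon. Among the measured compounds shown here, no measured pair exchanges one halogen for another at the same position. The related steps are a 3.8-fold lower number from compound 1 to compound 3 (0.58 log units; beyond the scatter), a 2.2-fold higher number from compound 1 to compound 2 (0.35 log units; beyond the scatter) and an 8.4-fold lower number from compound 2 to compound 3 (0.93 log units; beyond the scatter), but the two halogen additions sit at different positions, so the bearing on this swap is indirect. A step within the scatter, or at most a modest weakening, is expected. Compound 4 is estimated at 650 nM, with a range from 250 nM to 1700 nM. The expected step is a 1.3-fold higher number from compound 3 to compound 4 (0.10 log units; within the scatter).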

Compound 4, half-maximal inhibitory concentration: 1320 nM
Compound 4: middle estimate off by 2.0-fold (0.31 log units), on the low side; the range from low to high includes it.
By their numbers in this assay, from the lowest: compound 3; then compounds 4 and 1 (each within the scatter of the next); then compound 2.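

In this assay, among the compounds shown here, this carbon of the benzyl ring distinguishes between two halogens: bromo in place of chloro is the first same-position exchange, and it gives a step beyond the scatter (a 2.6-fold higher number from compound 3 to compound 4 (0.41 log units; beyond the scatter)). The 4-bromobenzyl compound does not separate from the unsubstituted benzyl (a 1.5-fold lower number from compound 1 to compound 4 (0.17 log units; within the scatter)), while 4-bromophenyl in place of 3-bromophenyl shows that the bromo's place on the ring also counts (a 3.3-fold lower number from compound 2 to compound 4 (0.52 log units; beyond the scatter)). Nothing available explains these differences. As far as these compounds go, whether fluoro, methyl or methoxy here would track chloro or bromo remains open.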